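Sulfonamide variation on the shared core: toward compound 4

This account rests on a few compounds, and the source may have more. Where it says the series, first, only, none or still open, it means among the compounds named here.

Measured so far in a functional assay on MCF7 cells (Homo sapiens) for antiproliferative activity, read by MTT assay, with a stated time of 72 h; a lower number here means a stronger inhibitor, a higher number a weaker inhibitor:
compound 1 `Cc1ccc(N(C)S(=O)(=O)C2CC3OC2C(c2ccc(NC(=O)CCCCCCC(=O)O)cc2)=C3c2ccc(O)cc2)cc1`: 23200 nM
compound 2 `CCN(c1ccc(C)cc1)S(=O)(=O)C1CC2OC1C(c1ccc(NC(=O)CCCCCCC(=O)O)cc1)=C2c1ccc(O)cc1`: 42300 nM
compound 3 `CCN(c1cccc(C)c1)S(=O)(=O)C1CC2OC1C(c1ccc(NC(=O)CCCCCCC(=O)O)cc1)=C2c1ccc(O)cc1`: 31800 nM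

Compound 1 gives the lowest of the three numbers, but its separation from the others is small: a 1.8-fold higher number from compound 1 to compound 2 (0.26 log units; within the scatter) and a 1.4-fold higher number from compound 1 to compound 3 (0.14 log units; within the scatter), both within the scatter, and the same holds for a 1.3-fold lower number from compound 2 to compound 3 (0.12 log units; within the scatter). Nothing among the three measured compounds rises above the usual spread of repeated measurements.

Compound 4 `CCN(c1ccc(O)cc1)S(=O)(=O)C1CC2OC1C(c1ccc(NC(=O)CCCCCCC(=O)O)cc1)=C2c1ccc(O)cc1` is the next unmeasured member. Relative to compound 1 it carries ethyl(4-hydroxyphenyl)amino in place of methyl(4-methylphenyl)amino on a sulfonyl sulfur. Among the measured compounds shown here, two measured steps bear on it in part: the methyl in place of hydrogen on a saturated chain carbon bound to a sulfonamide nitrogen, covered by a 1.8-fold higher number from compound 1 to compound 2 (0.26 log units; within the scatter), and the exchange of one substituent for another on the six-membered aromatic ring of carbon only, covered by a 1.3-fold lower number from compound 2 to compound 3 (0.12 log units; within the scatter). Both were within the scatter. For the measured compounds named here, no measured step covers a hydroxyl in place of a methyl on that ring, so that part of the change is untested.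

On the evidence at hand, the step from compound 1 to compound 4 is expected to be small, a 1.3-fold higher number from compound 1 to compound 4 (0.11 log units; within the scatter), with no direction beyond the scatter. Compound 4 is therefore estimated at 30000 nM in this assay, with a range from 12000 nM to 75000 nM.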

Compound 4, half-maximal inhibitory concentration: 46600 nM
Estimate against measurement, compound 4: 1.6-fold (0.19 log units) below; the range from low to high includes it.
By their numbers in this assay, from the lowest: compounds 1, 3, 2 and 4 (each within the scatter of the next).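

In this assay, hydroxy in place of methyl on an aromatic carbon gives a 1.1-fold higher number from compound 2 to compound 4 (0.04 log units; within the scatter), so this exchange, which brings a hydrogen-bond donor onto the ring carried by the sulfonamide nitrogen, does not separate the two compounds. The other two new steps agree with this: a 1.5-fold higher number from compound 3 to compound 4 (0.17 log units; within the scatter), and a 2.0-fold higher number from compound 1 to compound 4 (0.30 log units; within the scatter), so the combined change on the sulfonyl sulfur also stays within the scatter, and no substituent change among the four compounds stands out from the rest. No measurement at hand offers an explanation for this flat response.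

Still open, on these data alone, is whether an amine or a carboxylic acid on that same ring would give a step beyond the scatter. Also open, as far as these compounds go, is whether a longer chain than ethyl on the sulfonamide nitrogen, such as propyl or butyl, would do so.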